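The source may report more compounds than this note shows. Statements on the series, on what has been measured and on what is new or still open speak of the compounds shown alone.

Measured so far:

Compound 1, `O=C(NO)c1ccc(-c2cn([C@@H]3C[C@@H](C(=O)O)N(Cc4ccccc4)C3)nn2)cc1`. In an assay on Sf9 cells for inhibition of histone deacetylase 11 (Homo sapiens), read by fluorescence, tested at 0.5 uM (a lower number here means less inhibition, a higher number more inhibition at the concentration tested (going by the name of the read-out)), compound 1 gives < 10%, which is a limit of the measurement and not a number.
Compound 2, `O=C(/C=C/c1cn([C@@H]2C[C@@H](C(=O)O)N(CCCc3ccccc3)C2)nn1)NO`. In this assay compound 2 gives < 10%, again a limit and not a number.
Compound 3, `O=C(NO)c1ccc(-c2cn([C@H]3C[C@@H](C(=O)O)N(CCCc4ccccc4)C3)nn2)cc1`. In this assay compound 3 gives 14%.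

Compound 3 therefore stands as the only one of the three with a figure of its own; the other two sit at the limit, as noted in the limit of < 10% in this assay, at which 2 of the 3 values shown sit. The compound to follow is compound 4, `O=C(NO)c1ccc(-c2cn([C@@H]3C[C@@H](C(=O)O)N(CCCc4ccccc4)C3)nn2)cc1`, not yet measured. Between compound 3 and compound 4 the change is this: the two compounds have the same atoms and bonds and differ only in configuration as drawn: 1 of 2 stereo elements differ; a stereocentre at a saturated ring carbon is drawn S in compound 3 and R in compound 4. Among the measured compounds shown here, no step between two measured compounds is available here, so nothing shows how a change of configuration at that ring carbon moves the read-out in this assay. Given that the figure of compound 3 already lies close to the limit of this assay, the step from compound 3 to compound 4 is expected to stay within the usual scatter, a number 4 percentage points lower from compound 3 to compound 4 (within the scatter), with no clear direction. For compound 4 the expected read-out in this assay is 10%, in a range from 3% to 18%.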

Compound 4, a percentage reported as inhibition, at one concentration (the size of the read-out at that concentration, not a potency): 14%
For compound 4 the middle estimate is 4 percentage points below the measured one; measured number inside the range.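

Turning a stereocentre at a saturated ring carbon from S to R gives no change at the digits printed from compound 3 to compound 4 (within the scatter) in this assay, so this is the first direct reading of that change, and at this concentration it leaves no visible mark. The other two new steps are less firm: 4-(hydroxycarbamoyl)phenyl in place of 2-(hydroxycarbamoyl)ethenyl on an aromatic carbon gives a number at least 4 percentage points higher from compound 2 to compound 4 (that floor lies within the scatter), and phenethyl in place of phenyl on a saturated chain carbon bound to an amine nitrogen in a ring gives a number at least 4 percentage points higher from compound 1 to compound 4 (that floor lies within the scatter). Neither shows that the change raises the read-out, since each is only a floor and each starts from a limit, not a number: the limit of < 10% in this assay, at which 2 of the 4 values shown sit.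

With all the values shown so low, the compounds leave open whether the configuration at this ring carbon would matter in a compound with a much higher read-out. They also leave open how the read-out would respond to a methyl ester in place of the carboxylic acid, or to a longer chain on the amine nitrogen in the ring.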